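This account rests on a few compounds, and the source may have more. Where it says the series, first, only, none or still open, it means among the compounds named here.

Compound 1 `c1ccc(-c2nc[nH]n2)c(NCC2=NCCN2)c1`: 5.01 nM
Compound 2 `Cc1nc(-c2ccccc2NCC2=NCCN2)n(C)n1`: < 5020 nM
Compound 3 `CC(C)n1nccc1-c1ccccc1NCC1=NCCN1`: < 100000 nM

Among the compounds with values here, in an in vitro functional assay on cells (Fibroblast) for agonist activity at Alpha-1B adrenergic receptor (Homo sapiens) (on this read-out lower numbers stand for an effect already at smaller amounts and higher numbers for an effect only at larger amounts of compound), compound 1 gives 5.01 nM, the only value in this set that is a number. For compound 2 this assay reports only a limit, < 5020 nM. For compound 3 it likewise reports only a limit, < 100000 nM. Compound 4 `Cn1ccc(-c2ccccc2NCC2=NCCN2)n1` differs from compound 1 by 1-methyl-1H-pyrazol-3-yl in place of 1H-1,2,4-triazol-3-yl on an aromatic carbon. No measured step between any two of these compounds exists, so the size of this change cannot be read from the data. The step is expected to weaken the effect, a 12-fold higher number from compound 1 to compound 4 (1.08 log units; beyond the scatter), by more than the usual scatter. Compound 4 is therefore estimated at 60 nM, with a range from 6 nM to 600 nM.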

Compound 4, half-maximal effective concentration: 50.1 nM
Compound 4: the middle estimate sits 1.2-fold (0.08 log units) above what was measured, and the stated range covers the measured number.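

In this assay, within the data shown here, this is the first readable step at this place on the aromatic carbon: 1-methyl-1H-pyrazol-3-yl in place of 1H-1,2,4-triazol-3-yl gives a 10-fold higher number from compound 1 to compound 4 (1.00 log units; beyond the scatter). Compound 4, whose ring carries no hydrogen-bond donor, still gives a true number, 50.1 nM. The step thus shows that this position tolerates the loss of that donor with a modest change in the read-out.

The change alters the ring and adds a methyl together, and a plain 1H-pyrazol-3-yl would be needed to tell these two apart. Nothing shown bears on why the step has this size.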